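This account rests on a few compounds, and the source may have more. Where it says the series, first, only, none or still open, it means among the compounds named here.

Measured compounds and values in an ADME assay on L02 cells (Homo sapiens) for antiproliferative activity, read by MTT assay, with a stated time of 48 h; on this read-out higher numbers stand for weaker inhibition and lower numbers for stronger inhibition:

Compound 1, `N#CC1=C(N)Oc2c(c3nc4ccccc4nc3c3ccccc23)C12C(=O)N(Cc1cnnn1-c1ccc(Cl)cc1)c1ccccc12`: compound 1 gives > 50000 nM, which is a limit of this assay and not a number.
Compound 2, `N#CC1=C(N)Oc2c(c3nc4ccccc4nc3c3ccccc23)C12C(=O)N(Cc1cnnn1-c1ccc(S(N)(=O)=O)cc1)c1ccccc12`: compound 2 gives > 50000 nM, again a limit.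
Compound 3, `N#CC1=C(N)Oc2c(N)cc3nc4ccccc4nc3c2C12C(=O)N(Cc1cnnn1-c1cccc(Br)c1)c1ccccc12`: compound 3 gives > 50000 nM, also a limit.

Among the compounds with values here, the one step among measured compounds that differ in one place, a step that the two limits leave unreadable from compound 1 to compound 2, cannot be read for size, since both ends are limits. Compound 3 stands at the same limit as the other two; its value is not a number, so no ordering among compounds 1, 2 and 3 can be drawn. The whole set rests on (the limit of > 50000 nM in this assay, at which 3 of the 3 values shown sit), and nothing in the series has yet given a finite value in this assay.

Compound 4, `COc1ccc(OC)c(-n2nncc2CN2C(=O)C3(C(C#N)=C(N)Oc4c(N)cc5nc6ccccc6nc5c43)c3ccccc32)c1`, is not yet measured. It differs from compound 3 in one place: 2,5-dimethoxyphenyl in place of 3-bromophenyl on an aromatic nitrogen. Within the data shown here, no measured step bears on this change directly; the only measured step is unreadable, and all three known values are limits. The expectation for the step that the limit leaves unreadable from compound 3 to compound 4 is therefore that it stays within the scatter, with no direction to be read. Compound 4 is expected to give about 60000 nM, estimated between 25000 nM and 200000 nM, most likely again as a limit rather than a number.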

Compound 4, half-maximal inhibitory concentration: > 50000 nM
Compound 4: no number, only a limit; the forecaster's own chance of this, stated with the estimate: 80%; the middle value lies beyond the limit too.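

In this assay compound 4 gives > 50000 nM, which is a limit and not a number. With compound 3 also at a limit, the step from 3-bromophenyl to 2,5-dimethoxyphenyl between compound 3 and compound 4 cannot be read for size or direction. The compounds shown leave open whether any member of the series gives a finite value: the limit of > 50000 nM in this assay, at which 4 of the 4 values shown sit.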